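The source may hold more compounds than are shown below. What is called first, only, known or untested is meant among the compounds shown, and "the series" means these compounds.

Compound 1 `CCC(NC(=O)c1ccc(C(=N)N)cc1)C(C)(C)C(=O)N1CCC(CC(=O)O)CC1`: 1.3 h
Compound 2 `CC(C)(C(=O)N1CCC(CC(=O)O)CC1)C(NC(=O)c1ccc(C(=N)N)cc1)c1ccc2ccccc2c1`: 0.85 h

In an in vivo ADME assay on the whole organism (Cavia porcellus) (on this read-out lower numbers stand for a shorter-lived compound and higher numbers for a longer-lived compound), compound 2 at 0.85 h cannot be separated from compound 1 at 1.3 h, as the two lie within the scatter. Compound 3 `CC(C)(C(=O)N1CCC(CC(=O)O)CC1)C(NC(=O)c1ccc(C(=N)N)cc1)c1ccc(O)cc1` differs from compound 2 by 4-hydroxyphenyl in place of naphthalen-2-yl on a saturated chain carbon bound to an amide-type nitrogen and a saturated chain carbon. Within the data shown here, the only measured step bearing on this, a 1.5-fold lower number from compound 1 to compound 2 (0.18 log units; within the scatter), changed the group on the same carbon and stayed within the scatter. One step is thin evidence, and none tests 4-hydroxyphenyl, so no shift beyond the scatter is expected. The expected change is a 1.2-fold higher number from compound 2 to compound 3 (0.07 log units; within the scatter). For compound 3, the estimate is 1 h, with an expected range of 0.5 h to 2 h.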

Compound 3, half-life: 1.05 h
For compound 3 the middle estimate is 1.1-fold (0.02 log units) below the measured one; measured number inside the range.
By their numbers in this assay, from the lowest: compounds 2, 3 and 1 (each within the scatter of the next).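

In this assay, putting 4-hydroxyphenyl on this carbon gives a 1.2-fold higher number from compound 2 to compound 3 (0.09 log units; within the scatter) when it replaces naphthalen-2-yl and a 1.2-fold lower number from compound 1 to compound 3 (0.09 log units; within the scatter) when it replaces ethyl, so both steps stay within the scatter. The half-life therefore does not separate these three groups, even though 4-hydroxyphenyl is the only one carrying a hydrogen-bond donor and acceptor. No measurement shown gives a reason for this. Still open, as far as these compounds go, is whether an amine or a carboxylic acid on this carbon would shift the half-life beyond the scatter.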